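A Shorter Amine Tail on the Shared Core

This account rests on a few compounds, and the source may have more. Where it says the series, first, only, none or still open, it means among the compounds named here.

Compound 1 `CN(C)CCCOc1ccc(Nc2nccc(-c3cccnc3)n2)cc1` is the starting point. In a functional assay for inhibition, with Homo sapiens as the target (a higher number here means a weaker inhibitor, a lower number a stronger inhibitor), compound 1 gives 600 nM, the lowest of the two numbers shown. Compound 2 `Cc1cc(C)cc(Nc2nccc(-c3cc(C)oc3C)n2)c1` gives 4100 nM in this assay, a gap beyond the usual scatter. Compound 3 `Cc1cc(C)cc(Nc2ncc(C)c(-c3cccnc3)n2)c1` reaches only a limit of this assay, > 24000 nM, so no number is known for it (the limit of > 24000 nM in this assay, at which 1 of the 3 values shown sits). Compound 4 `CN(C)c1ccc(Nc2nccc(-c3cccnc3)n2)cc1` has not yet been measured; it differs from compound 1 in one place: dimethylamino in place of 3-(dimethylamino)propoxy on an aromatic carbon. For the measured compounds named here, with no measured step of this kind to lean on, a modest loss is the expectation here. Compound 4 is expected to give about 1500 nM in this assay, within 400 nM to 6000 nM. That estimate means an expected step of a 2.5-fold higher number from compound 1 to compound 4 (0.40 log units; beyond the scatter), slightly beyond the scatter.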

Compound 4, half-maximal inhibitory concentration: 2800 nM
Estimate against measurement, compound 4: 1.9-fold (0.27 log units) below, and the stated range covers the measured number.
By their numbers in this assay, from the lowest: compound 1; then compounds 4 and 2 (each within the scatter of the next). At a limit, above all of these: compound 3.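

In this assay, the first step measured at this position, replacing 3-(dimethylamino)propoxy with dimethylamino, gives a 4.7-fold higher number from compound 1 to compound 4 (0.67 log units; beyond the scatter). The group on this aromatic carbon therefore affects the read-out, although the shorter dimethylamino group still gives a measured number rather than a limit. Nothing shown here explains the loss.

Two things change together in this step, the chain and its oxygen, and the compounds shown leave open which one counts. A 2-(dimethylamino)ethoxy chain or a plain methoxy group at this position would help to separate them.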